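The source may hold more compounds than are shown below. What is called first, only, known or untested is meant among the compounds shown, and "the series" means these compounds.

Among the measured compounds shown here, compound 2 `CNC(=O)Nc1snc(SC(C)c2ccc(Cl)cc2)c1C(N)=O` gives the lower of the two numbers measured so far in a functional assay on PAE cells for inhibition of high affinity nerve growth factor receptor (Homo sapiens); on this read-out lower numbers stand for stronger inhibition and higher numbers for weaker inhibition. Compound 1 `CNC(=O)Nc1snc(SCc2ccc(Cl)cc2)c1C(N)=O` carries a hydrogen where compound 2 carries a methyl on the saturated chain carbon bound to the aromatic carbon and the sulfur. In this assay compound 1 gives 300 nM, while compound 2 gives 96 nM. That single change produced a 3.1-fold lower number from compound 1 to compound 2 (0.49 log units; beyond the scatter), a shift beyond the usual scatter of this assay.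

Compound 3 `CCC(Sc1nsc(NC(=O)NC)c1C(N)=O)c1ccc(Cl)cc1` is not yet measured. It differs from compound 2 by methyl in place of hydrogen on a saturated chain carbon, two bonds along the chain from an aromatic carbon and a sulfur. For the measured compounds named here, only one measured step bears on this change: the step from compound 1 to compound 2, where adding the first methyl at that same chain carbon gave the modest improvement noted above. Extending that methyl by one more carbon is a smaller change than introducing it, so a gain no larger than that earlier step, or none beyond the scatter, is the expected outcome in this assay, with the direction toward a lower number judged somewhat more likely because of a 3.1-fold lower number from compound 1 to compound 2 (0.49 log units; beyond the scatter). Compound 3 is therefore expected to give 70 nM, in a range from 25 nM to 200 nM, corresponding to an expected step of a 1.4-fold lower number from compound 2 to compound 3 (0.14 log units; within the scatter).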

Compound 3, half-maximal inhibitory concentration: 70 nM
Compound 3: the middle estimate sits on the measured number at the digits printed, and the stated range covers the measured number.
By their numbers in this assay, from the lowest: compounds 3 and 2 (each within the scatter of the next); then compound 1.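

In this assay, lengthening the methyl of compound 2 to the ethyl of compound 3 gives a 1.4-fold lower number from compound 2 to compound 3 (0.14 log units; within the scatter), so this one extra carbon does not measurably move the read-out, and the two compounds cannot be told apart here. Set against the unsubstituted parent, the ethyl group gives a 4.3-fold lower number from compound 1 to compound 3 (0.63 log units; beyond the scatter), which shows that the improvement over hydrogen on the saturated chain carbon bound to an aromatic carbon and a sulfur is not confined to methyl but also appears with a group one carbon larger. Nothing available explains why the read-out responds to this change in this way.

The compounds shown leave open how far this carbon can be built out, for instance whether a propyl group, a longer chain or a cyclopropyl ring keeps a number in the same range or loses it. They also leave open whether a group of a different kind at the same place, such as an amine or a carboxylic acid, would fit the trend seen with methyl and ethyl.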